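The source may hold more compounds than are shown below. What is called first, only, known or untested is meant among the compounds shown, and "the series" means these compounds.

Working notes on the series. For the measured compounds named here, the shared core carries a pendant chain on an aromatic oxygen, and the three measured members differ only in that chain. Compound 1 `O=c1c(-c2ccc(O)cc2)coc2cc(OCCOCCOCCO)ccc12` gives 40 nM in an assay (Cricetulus griseus) for inhibition of aldehyde dehydrogenase, mitochondrial (Homo sapiens); on this read-out lower numbers stand for stronger inhibition and higher numbers for weaker inhibition. Compound 2 `NCCCCCCOc1ccc2c(=O)c(-c3ccc(O)cc3)coc2c1` gives 100 nM in this assay. Compound 3 `O=C(O)CCCCOc1ccc2c(=O)c(-c3ccc(O)cc3)coc2c1` gives 100 nM in this assay. Compound 3 thus sits level with compound 2 at the top of the three numbers, and the distance from the lowest number is a 2.5-fold higher number from compound 1 to compound 3 (0.40 log units; beyond the scatter); the comparison of the chain ends, no change at the digits printed from compound 2 to compound 3 (within the scatter), shows that carboxy and aminoethyl are not told apart here.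

Compound 4 `CCOC(=O)COc1ccc2c(=O)c(-c3ccc(O)cc3)coc2c1` is not yet measured. The change is ethoxycarbonyl in place of 3-carboxypropyl on a saturated chain carbon bound to an oxygen on an aromatic ring. Going by the values given here, the steps that bear on it are the modest one, a 2.5-fold higher number from compound 1 to compound 3 (0.40 log units; beyond the scatter), and the flat one, no change at the digits printed from compound 2 to compound 3 (within the scatter): variation of this chain has moved the number by at most a modest amount. A shorter chain ending in an ester is therefore expected to stay near compound 3, with a small shift upward allowed, so compound 4 is expected to give 130 nM in this assay, within 50 nM to 350 nM. The step expected from compound 3 to compound 4 is a 1.3-fold higher number from compound 3 to compound 4 (0.11 log units; within the scatter).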

Compound 4, half-maximal inhibitory concentration: 130 nM
The estimate for compound 4 equals the measured number at the digits printed; measured number inside the range.
By their numbers in this assay, from the lowest: compound 1; then compounds 2, 3 and 4 (each within the scatter of the next).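

Swapping the acid end for an ester on a shorter chain does not separate compound 4 from compound 3 in this assay (a 1.3-fold higher number from compound 3 to compound 4 (0.11 log units; within the scatter)), although ethoxycarbonyl has 5 heavy atoms and 0 hydrogen-bond donors where 3-carboxypropyl has 6 and 1; compound 4 is likewise not told apart from the amine-ended compound 2 (a 1.3-fold higher number from compound 2 to compound 4 (0.11 log units; within the scatter)). The position on the saturated chain carbon bound to an oxygen on an aromatic ring therefore tolerates this change, while compound 1 stays apart, now by the largest step in the series, still modest (a 3.3-fold higher number from compound 1 to compound 4 (0.51 log units; beyond the scatter)). No measured evidence accounts for these numbers.

Open, as far as these compounds go, is whether a carboxylic acid on the short chain of compound 4 would read differently from its ester, and whether an ethyl ester on a longer chain would match it. Also open, from the compounds shown here alone, is whether the lower number of compound 1 goes with its terminal hydroxyl or with its ether oxygens.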